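Replacing a Benzyl Group with a Urea on a Weak Core

The source may report more compounds than this note shows. Statements on the series, on what has been measured and on what is new or still open speak of the compounds shown alone.

Compound 1 `N#Cc1ccccc1CN1CCc2c(sc(NC(=O)c3ccccc3Cl)c2C(N)=O)C1` is one of three analogues built on a shared core. In a functional assay on HeLa cells (Homo sapiens) for antiproliferative activity, with a stated time of 24 h (on this read-out higher numbers stand for weaker inhibition and lower numbers for stronger inhibition), compound 1 gives > 50000 nM, which is a limit of the assay rather than a number (the limit of > 50000 nM in this assay, at which 1 of the 3 values shown sits). Compound 2 `NC(=O)c1c(NC(=O)c2ccccc2F)sc2c1CCN(Cc1cccc(Cl)c1)C2` gives 49500 nM in this assay, and compound 3 `NC(=O)c1c(NC(=O)c2ccccc2F)sc2c1CCN(Cc1ccc(Cl)cc1Cl)C2` gives 27500 nM; the step of a 1.8-fold lower number from compound 2 to compound 3 (0.26 log units; within the scatter) shows how little the aryl substituent moved the read-out. Compound 4 `NC(=O)c1c(NC(=O)c2ccccc2Cl)sc2c1CCN(C(=O)Nc1c(Cl)cccc1Cl)C2` differs from compound 1 by (2,6-dichlorophenyl)carbamoyl in place of 2-cyanobenzyl on an amine nitrogen in a ring. Going by the values given here, no measured step alters this nitrogen in the same way; the nearest comparison, a 1.8-fold lower number from compound 2 to compound 3 (0.26 log units; within the scatter), concerns the aryl ring alone. Compound 4 is therefore expected to remain near the limit, with the step of an at least 1.1-fold lower number from compound 1 to compound 4 (0.04 log units; that floor lies within the scatter) estimated to be small. The value of compound 4 is estimated at 45000 nM, with a range from 15000 nM to 150000 nM.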

Compound 4, half-maximal inhibitory concentration: 27200 nM
For compound 4 the middle estimate is 1.7-fold (0.22 log units) above the measured one, within the range that was stated.
By their numbers in this assay, from the lowest: compounds 4, 3 and 2 (each within the scatter of the next). At a limit, above all of these: compound 1.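

At the amine nitrogen in a ring, (2,6-dichlorophenyl)carbamoyl in place of 2-cyanobenzyl gives, in this assay, an at least 1.8-fold lower number from compound 1 to compound 4 (0.26 log units; that floor lies within the scatter). The earlier compounds carry only substituted benzyl groups on this nitrogen, so this is the one change shown that places a carbonyl there. The value of compound 1 is a limit, and the true size of this step stays unread: the limit of > 50000 nM in this assay, at which 1 of the 4 values shown sits.

The compounds shown leave open whether an acetyl group, a longer alkyl chain or a carboxylic acid on this nitrogen would move the read-out beyond the scatter. They also leave open whether the two chlorines of the (2,6-dichlorophenyl)carbamoyl group matter.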